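Shortening an Ester Side Chain to a Carboxylic Acid

The compounds below may be only part of what the source reports. "The series", "measured", "known", "first", "only" and "open" are said of these compounds alone.

Compound 1 `CCn1c(C(=O)NCCC(=O)OC)ccc1C(CC)(CC)c1ccc(C#CC(O)(CC)CC)c(C)c1`: > 50 nM in an assay on cells for agonist activity at vitamin D3 receptor (Homo sapiens), read by microscopy; on this read-out lower numbers stand for an effect already at smaller amounts and higher numbers for an effect only at larger amounts of compound
Compound 2 `C#CCCOC(=O)c1ccc(C(CC)(CC)c2ccc(C#CC(O)(CC)CC)c(C)c2)n1CC`: > 50 nM in this assay

In this assay compound 1 gives only a limit, > 50 nM. Compound 2 likewise gives only a limit, > 50 nM. Going by the values given here, the single measured step, a step that the two limits leave unreadable from compound 1 to compound 2, therefore cannot be read, because of the limit of > 50 nM in this assay, at which 2 of the 2 values shown sit. Compound 3 `CCn1c(C(=O)NCC(=O)O)ccc1C(CC)(CC)c1ccc(C#CC(O)(CC)CC)c(C)c1` differs from compound 1 in a neighbouring part of the same side chain: carboxy in place of (methoxycarbonyl)methyl on a saturated chain carbon bound to an amide-type nitrogen. Among the compounds with values here, no measured step bears on this change, so no size or direction can be expected beyond the scatter. Compound 3 is expected to give 100 nM, between 30 nM and 500 nM, a step that the limit leaves unreadable from compound 1 to compound 3, most likely again only a limit.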

Compound 3, half-maximal effective concentration: 9.36 nM
The estimate for compound 3 lay 11-fold (1.03 log units) above the measured number; measured number outside the range, below it.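

Going by these compounds alone, compound 3 is the only compound here with a readable number in this assay, so this side chain can give a measurable effect. Placing (carboxymethyl)amino on the carbonyl carbon gives an at least 5.3-fold lower number from compound 1 to compound 3 (0.72 log units; beyond the scatter) and an at least 5.3-fold lower number from compound 2 to compound 3 (0.72 log units; beyond the scatter). Both steps are open-ended because their starting compounds give only a limit: the limit of > 50 nM in this assay, at which 2 of the 3 values shown sit.

The change from compound 1 to compound 3 both shortens the chain and replaces the ester with a free acid, so the cause remains open. A 2-carboxyethyl chain, keeping the longer length with the acid, would help separate these two changes.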